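This account rests on a few compounds, and the source may have more. Where it says the series, first, only, none or still open, it means among the compounds named here.

Measured so far:
compound 1 `O=C(Nc1cccc(F)c1)N1CCN(c2ccnc(Cl)n2)CC1` — 952 nM
compound 2 `O=C(Nc1ccc(C(F)(F)F)cc1)N1CCN(c2ccnc(Cl)n2)CC1` — 874 nM

Both compounds share a core and differ only in the substituent on the terminal phenyl ring. In an assay on isolated protein for antagonist activity at transient receptor potential cation channel subfamily V member 1 (Homo sapiens) (a lower number here means a stronger inhibitor, a higher number a weaker inhibitor), compound 2 gives 874 nM, the lower of the two numbers, while compound 1 gives 952 nM; the gap between them lies within the usual scatter, so the two stand as equals.

Compound 3 `O=C(Nc1ccc(Cl)cc1)N1CCN(c2ccnc(Cl)n2)CC1` has not been measured. It is derived from compound 2 by the change (chloro in place of trifluoromethyl on an aromatic carbon). Among the compounds with values here, no step between measured compounds bears on this change, so the expectation rests only on the two numbers seen, which themselves show little spread across this position. Compound 3 is therefore expected to fall at 900 nM, within a range from 300 nM to 2700 nM. The step from compound 2 to compound 3 is estimated at a 1.0-fold higher number from compound 2 to compound 3 (0.01 log units; within the scatter), not beyond the scatter.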

Compound 3, half-maximal inhibitory concentration: 1250 nM
The estimate for compound 3 lay 1.4-fold (0.14 log units) below the measured number, within the range that was stated.
By their numbers in this assay, from the lowest: compounds 2, 1 and 3 (each within the scatter of the next).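

In this assay the step of a 1.4-fold higher number from compound 2 to compound 3 (0.16 log units; within the scatter) lies within the scatter, so on this aromatic carbon, para to a large group, chloro with its 1 heavy atom is not told apart from trifluoromethyl with its 4 heavy atoms. The step of a 1.3-fold higher number from compound 1 to compound 3 (0.12 log units; within the scatter) also lies within the scatter, which means that 4-chlorophenyl in place of 3-fluorophenyl on the amide-type nitrogen leaves the two compounds as equals and the three terminal phenyl rings shown do not separate. No measurement here offers an explanation for this flat result. Going by these compounds, whether an amine, a carboxylic acid or a longer chain at the same position would stay level with chloro and trifluoromethyl remains open. So does the effect of replacing the terminal phenyl ring with a saturated ring such as cyclohexyl.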